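The source may hold more compounds than are shown below. What is called first, only, known or untested is meant among the compounds shown, and "the series" means these compounds.

Measured so far:
compound 1 `COc1cc2c(Oc3ccc(NC(=O)c4nn(-c5ccccc5C)c(=O)cc4C)cc3F)ccnc2cc1OCCCN1CCC(C)CC1` gives 2260 nM in a functional assay on NCI-H460 cells (Homo sapiens) for inhibition, read by MTT assay, with a stated time of 72 h; on this read-out lower numbers stand for stronger inhibition and higher numbers for weaker inhibition
compound 2 `COc1cc2c(Oc3ccc(NC(=O)c4nn(-c5ccccc5OC(F)(F)F)c(=O)cc4C)cc3F)ccnc2cc1OCCCN1CCC(C)CC1` gives 290 nM in this assay
compound 3 `COc1cc2c(Oc3ccc(NC(=O)c4nn(-c5ccc(Cl)cc5)c(=O)cc4C)cc3F)ccnc2cc1OCCCN1CCCC1` gives 360 nM in this assay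

Compound 3 stands at the second highest of the three numbers; its number and that of compound 2 lie within the scatter of each other, while compound 1 sits apart with the clearly higher number. Among the compounds with values here, the only single-point step in the set, a 7.8-fold lower number from compound 1 to compound 2 (0.89 log units; beyond the scatter), concerns the group on the aryl ring and not the chain end, so it does not bear on the present change. Compound 4 `COc1cc2c(Oc3ccc(NC(=O)c4nn(-c5ccc(Cl)cc5)c(=O)cc4C)cc3F)ccnc2cc1OCCCN1CCC(C)CC1` differs from compound 3 by 4-methylpiperidin-1-yl in place of pyrrolidin-1-yl on a saturated chain carbon, three bonds along the chain from an oxygen on an aromatic ring. Within the data shown here, compounds 1 and 2 carry the 4-methylpiperidin-1-yl end, but they differ from compound 3 in the aryl group as well, so no measured pair isolates this exchange. With nothing pointing either way, no step beyond the scatter is expected in this assay. The expected step from compound 3 to compound 4 is no change at the digits printed from compound 3 to compound 4 (within the scatter). Compound 4 is therefore estimated at 360 nM, with a range from 150 nM to 900 nM.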

Compound 4, half-maximal inhibitory concentration: 370 nM
Compound 4: middle estimate off by 1.0-fold (0.01 log units), on the low side; the range from low to high includes it.
By their numbers in this assay, from the lowest: compounds 2, 3 and 4 (each within the scatter of the next); then compound 1.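

In this assay, 4-methylpiperidin-1-yl in place of pyrrolidin-1-yl at the end of the propyl chain gives a 1.0-fold higher number from compound 3 to compound 4 (0.01 log units; within the scatter), so with 4-chlorophenyl on the aromatic nitrogen this exchange does not separate the two chain ends. With 4-methylpiperidin-1-yl held fixed, the aryl group can now be read directly: a 1.3-fold higher number from compound 2 to compound 4 (0.11 log units; within the scatter) does not separate 4-chlorophenyl from 2-(trifluoromethoxy)phenyl, whereas a 6.1-fold lower number from compound 1 to compound 4 (0.79 log units; beyond the scatter) sets 2-methylphenyl apart from 4-chlorophenyl. No data are at hand that account for these steps.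

Pyrrolidin-1-yl appears here only with 4-chlorophenyl, so it remains open whether the chain end is equally silent with 2-methylphenyl on the aromatic nitrogen. Also open, from the compounds shown here alone, is how a morpholine or a dimethylamino group at the chain end, or a longer chain, would read in this assay.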